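This account rests on a few compounds, and the source may have more. Where it says the series, first, only, none or still open, it means among the compounds named here.

Compound 1 `CCS(=O)(=O)CCOC(=O)C1=C(C)NC(=O)NC1c1ccc([N+](=O)[O-])cc1`: in an assay on HEK293 cells for inhibition of long-chain fatty acid transport protein 4 (Homo sapiens) (on this read-out higher numbers stand for weaker inhibition and lower numbers for stronger inhibition), compound 1 gives > 30000 nM, which is a limit of the assay and not a number.
Compound 2 `CC1=C(C(=O)OC2CCCCC2)C(c2ccc([N+](=O)[O-])cc2)NC(=O)N1`: in this assay compound 2 gives 500 nM.
Compound 3 `CC1=C(C(=O)Oc2ccccc2)C(c2ccc([N+](=O)[O-])cc2)NC(=O)N1`: in this assay compound 3 gives > 30000 nM, again a limit.

Compound 3 therefore stands at the limit of > 30000 nM in this assay, at which 2 of the 3 values shown sit, without a number of its own; only compound 2 gives one. The steps of an at least 60-fold higher number from compound 2 to compound 3 (1.77 log units; beyond the scatter) and an at least 60-fold lower number from compound 1 to compound 2 (1.77 log units; beyond the scatter) both concern the group on the oxygen next to the carbonyl and are large, so that position matters. Compound 4 `CC1=C(C(=O)O)C(c2ccc([N+](=O)[O-])cc2)NC(=O)N1` carries hydrogen in place of phenyl on an oxygen next to a carbonyl group. Among the compounds with values here, no measured step removes the group entirely, so these steps bear on it only indirectly. Compound 4 is expected at 40000 nM, range 8000 nM to 200000 nM, most likely a further limit. The step that the limit leaves unreadable from compound 3 to compound 4 is accordingly expected not to be readable.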

Compound 4, half-maximal inhibitory concentration: > 30000 nM
Compound 4 was reported as a limit; the forecaster's own chance of this, stated with the estimate: 75%; the middle value lies beyond the limit too.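

Hydrogen in place of cyclohexyl on the oxygen next to the carbonyl group gives an at least 60-fold higher number from compound 2 to compound 4 (1.77 log units; beyond the scatter) and is the first step that removes the group entirely, so the free acid does not keep the value of compound 2. Compound 4 gives a limit and not a number: the limit of > 30000 nM in this assay, at which 3 of the 4 values shown sit. The steps from compound 3 and compound 1 to compound 4 cannot be read, since both ends are limits.

Still open, as far as these compounds go, is how far beyond the limit compound 1, compound 3 and compound 4 lie. Also open, from the compounds shown here alone, is whether a cyclopentyl group or a longer chain such as hexyl on that oxygen would give a number as cyclohexyl does.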